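Methyl on the anilide ring in two related thiourea and urea cores

This account rests on a few compounds, and the source may have more. Where it says the series, first, only, none or still open, it means among the compounds named here.

Compound 1, with the structure `CC1=C(C(=O)Nc2ccccc2)C(c2cn(-c3ccccc3)nc2-c2ccccc2)NC(=S)N1`, serves as the starting point. In a functional assay on MCF7 cells (Homo sapiens) for inhibition, read by sulforhodamine B assay, with a stated time of 24 h (on this read-out higher numbers stand for weaker inhibition of growth and lower numbers for stronger inhibition of growth), compound 1 gives 88200 nM. Compound 2, with the structure `CC1=C(C(=O)Nc2ccc(C)cc2)C(c2cn(-c3ccccc3)nc2-c2ccccc2)NC(=S)N1`, carries one change from compound 1, namely (methyl in place of hydrogen on an aromatic carbon). In this assay compound 2 gives 56100 nM, and the step of a 1.6-fold lower number from compound 1 to compound 2 (0.20 log units; within the scatter) stays inside the usual spread of repeated measurements, so the two numbers cannot be told apart with confidence.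

Compound 3, with the structure `CC1=C(C(=O)Nc2ccccc2)C(c2cn(-c3ccccc3)nc2-c2ccc(Cl)cc2)NC(=O)N1`, rests on a different core; how its core differs from that of compound 1 is not broken down here. In this assay compound 3 gives 65500 nM, which sits close to both earlier numbers, and none of the three measured compounds can be called stronger or weaker than another on this evidence.

Compound 4, with the structure `CC1=C(C(=O)Nc2ccc(C)cc2)C(c2cn(-c3ccccc3)nc2-c2ccc(Cl)cc2)NC(=O)N1`, has not been measured. Going by the values given here, it differs from compound 3 by methyl in place of hydrogen on an aromatic carbon, and this is the same change, at the same kind of place, as the one from compound 1 to compound 2. The expectation is therefore that the step of a 1.6-fold lower number from compound 3 to compound 4 (0.19 log units; within the scatter) will be small, of the size seen in a 1.6-fold lower number from compound 1 to compound 2 (0.20 log units; within the scatter), and still within the scatter. On that basis compound 4 is estimated to give about 42000 nM in this assay, with a likely range from 20000 nM to 90000 nM.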

Compound 4, concentration for 50% growth inhibition: 69700 nM
Compound 4: middle estimate off by 1.7-fold (0.22 log units), on the low side; low and high end bracket the measured number.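

Carrying the methyl onto the anilide ring of the second core gives, in this assay, a 1.1-fold higher number from compound 3 to compound 4 (0.03 log units; within the scatter). Set beside the earlier step on the first core, the two cannot be told apart: the same change on two cores in this assay, a 1.6-fold lower number (0.20 log units; within the scatter) from compound 1 to compound 2 and a 1.1-fold higher number (0.03 log units; within the scatter) from compound 3 to compound 4, 1.7-fold (0.22 log units) apart, within the scatter of two such steps

This agrees with the change behaving alike on both cores, but it is weak support, as neither step can be separated from the spread of repeated measurements, and it does not show that the methyl has any real effect on growth inhibition on either core.

The compounds shown leave open whether another group in place of that hydrogen on the anilide ring, such as a chlorine, a methoxy group, an amine or a carboxylic acid, would give a step that stands clear of the scatter. They also leave open whether such a larger step would carry from one core to the other, which is the test that two steps inside the scatter cannot provide.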